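A Bromophenyl Swap on the Amide Nitrogen of Compound 2

A few compounds are considered here, and "the series" means these few. Any claim that something is new, unique, unknown or untested is made for them only; others in the source may bear on it.

Of the compounds shown here, two have been measured in a functional assay on Jurkat cells (Homo sapiens) for inhibition; a lower number here means a stronger inhibitor, a higher number a weaker inhibitor. Compound 1 `Cc1c(C(=O)N[C@H](C(=O)NC(CC(=O)O)C(=O)CF)C(C)C)n(C)c2ccccc12` gives 1300 nM in this assay. Among the measured compounds shown here, compound 2 `C[C@H](NC(=O)C(=O)NCc1ccccc1)C(=O)N[C@@H](CC(=O)O)C(=O)COc1c(F)c(F)cc(F)c1F` gives 300 nM and stands lowest of the two numbers; its only neighbour is compound 1, whose number is higher by a margin beyond the scatter. Compound 3 `C[C@H](NC(=O)C(=O)Nc1ccccc1Br)C(=O)N[C@@H](CC(=O)O)C(=O)COc1c(F)c(F)cc(F)c1F` has not yet been measured. It differs from compound 2 in one place: 2-bromophenyl in place of benzyl on an amide-type nitrogen. No measured pair shows this change, so the account has no precedent for it among these compounds. The change keeps the heavy-atom, donor and acceptor counts unchanged, putting 2-bromophenyl in place of benzyl on an amide-type nitrogen whose other neighbour is a carbonyl carbon. The step is expected to be modest, a 1.3-fold higher number from compound 2 to compound 3 (0.12 log units; within the scatter), with no confident direction beyond the scatter. Compound 3 is estimated at 400 nM, within 120 nM to 1400 nM.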

Compound 3, half-maximal inhibitory concentration: 75 nM
The estimate for compound 3 lay 5.3-fold (0.73 log units) above the measured number; the whole stated range lies above it.
By their numbers in this assay, from the lowest: compound 3; then compound 2; then compound 1.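

Putting 2-bromophenyl in place of benzyl on the amide-type nitrogen gives a 4.0-fold lower number from compound 2 to compound 3 (0.60 log units; beyond the scatter) in this assay, which shows that this position is sensitive to the group it carries. Both groups hold one six-membered aromatic ring of carbon only and the same heavy-atom, donor and acceptor counts, so a step beyond the scatter can occur with those counts unchanged. No measurement given here explains the step.

This single step cannot separate the arrival of the bromine from the loss of the carbon linking the benzyl ring to the nitrogen: plain phenyl and 2-bromobenzyl on the same nitrogen would be needed to part the two. On these data alone, it also remains open whether chlorine or a methyl group in place of the bromine would give a similar number.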